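Swapping the aryl group on the ring nitrogen

The source may report more compounds than this note shows. Statements on the series, on what has been measured and on what is new or still open speak of the compounds shown alone.

Compound 1 `CCCCCCNc1nc(SCc2ccc(C(F)(F)F)cc2)nc2ccccc12` carries a hexyl group on a nitrogen on an aromatic ring, and in a functional assay on HGC-27 cells (Homo sapiens) for cytotoxicity, read by MTT assay, with a stated time of 72 h (a lower number here means a stronger inhibitor, a higher number a weaker inhibitor), compound 1 gives 23900 nM. Compound 2 `FC(F)(F)c1ccc(CSc2nc(Nc3ccccc3C(F)(F)F)c3ccccc3n2)cc1` puts a 2-(trifluoromethyl)phenyl there, and in this assay compound 2 reaches only the assay limit, > 50000 nM. Compound 3 `COc1ccccc1Nc1nc(SCc2ccc(C(F)(F)F)cc2)nc2ccccc12` puts a 2-methoxyphenyl there, and in this assay compound 3 likewise reaches only the limit, > 50000 nM. Compound 3 thus stands at the weak end of what has been measured, sharing (the limit of > 50000 nM in this assay, at which 2 of the 3 values shown sit). The steps of an at least 2.0-fold higher number from compound 1 to compound 2 (0.32 log units; beyond the scatter) and an at least 2.0-fold higher number from compound 1 to compound 3 (0.32 log units; beyond the scatter) show that either aryl group weakens inhibition, while a step that the two limits leave unreadable from compound 2 to compound 3 cannot be read. Compound 4 `FC(F)(F)c1ccc(CSc2nc(Nc3cccc(Cl)c3)c3ccccc3n2)cc1` differs from compound 3 by 3-chlorophenyl in place of 2-methoxyphenyl on a nitrogen on an aromatic ring. For the measured compounds named here, no measured step tests this exact swap, so the change expected in this assay is a number no higher from compound 3 to compound 4 (the limit leaves the size open), most likely ending at a limit again. Compound 4 is expected at 50000 nM, within 20000 nM to 120000 nM.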

Compound 4, half-maximal inhibitory concentration: 19900 nM
Compound 4: middle estimate off by 2.5-fold (0.40 log units), on the high side; the measured number lies below the stated range.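

An aryl group on this nitrogen does not by itself cost activity: 3-chlorophenyl gives an at least 2.5-fold lower number from compound 3 to compound 4 (0.40 log units; beyond the scatter) and also an at least 2.5-fold lower number from compound 2 to compound 4 (0.40 log units; beyond the scatter) in this assay. Against the hexyl group, the change is a 1.2-fold lower number from compound 1 to compound 4 (0.08 log units; within the scatter) so here an aryl group can match that chain. Nothing measured here explains the difference among the aryl groups.

From the compounds shown here alone, whether the chlorine itself or its place on the ring drives the change stays open. So does the effect of an amine or a carboxylic acid on this aryl ring, or of a chain longer than hexyl on the nitrogen.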